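Series notes: sulfonamide chain cut to a nitrile

The source may report more compounds than this note shows. Statements on the series, on what has been measured and on what is new or still open speak of the compounds shown alone.

Measured so far:
compound 1 `CC(C)(N)C(=O)N[C@H](COCc1ccccc1)c1nnnn1Cc1ccc(NS(C)(=O)=O)cc1` — an assay on isolated protein for displacement of a labelled ligand from growth hormone secretagogue receptor type 1 (Homo sapiens), with a stated time of 1 h; on this read-out lower numbers stand for stronger inhibition and higher numbers for weaker inhibition > 5000 nM
compound 2 `CC(C)(N)C(=O)N[C@H](COCc1ccccc1)c1nnnn1CCCCCNS(C)(=O)=O` — this assay > 5000 nM

In this assay compound 1 gives > 5000 nM, a limit of the assay. Compound 2 gives > 5000 nM, likewise a limit. Within the data shown here, the step that the two limits leave unreadable from compound 1 to compound 2 is therefore unreadable, and compound 2 stands at the limit of > 5000 nM in this assay, at which 2 of the 2 values shown sit, together with the only other value shown.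

Compound 3 `CC(C)(N)C(=O)N[C@H](COCc1ccccc1)c1nnnn1CCC#N` carries the change (cyano in place of 3-(methanesulfonamido)propyl on a saturated chain carbon, two bonds along the chain from an aromatic nitrogen). Among the measured compounds shown here, no measured step reads on this change, since a step that the two limits leave unreadable from compound 1 to compound 2 gives no size. Compound 3 is expected at 8000 nM, within 2000 nM to 30000 nM. The expected step that the limit leaves unreadable from compound 2 to compound 3 is thus none beyond the scatter, with the value most likely remaining a limit.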

Compound 3, inhibition constant: 2940 nM
Beside the measured number, compound 3's estimate is 2.7-fold (0.43 log units) above it; low and high end bracket the measured number.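

Among these compounds, compound 3, with its 2-cyanoethyl group, gives the first number in this assay that is not a limit: 2940 nM. The change reads as an at least 1.7-fold lower number from compound 2 to compound 3 (0.23 log units; that floor lies within the scatter), and the comparison with the aryl chain reads as an at least 1.7-fold lower number from compound 1 to compound 3 (0.23 log units; that floor lies within the scatter), so neither step is established beyond the scatter. Compound 1 and compound 2 each remain at a limit of the assay: the limit of > 5000 nM in this assay, at which 2 of the 3 values shown sit.

Open, as far as these compounds go, is whether the cyano end or the shorter chain accounts for the number. A longer chain ending in cyano, or a 2-aminoethyl or carboxylic acid chain of the same length, would separate the two.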